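The source may hold more compounds than are shown below. What is called first, only, known or untested is meant among the compounds shown, and "the series" means these compounds.

Compound 2 `CC(C(=O)NCc1ccc(C2CC2)cc1)c1ccc(NS(C)(=O)=O)c(F)c1` and compound 1 `CC(C(=O)NCc1ccc(C(F)(F)F)cc1)c1ccc(NS(C)(=O)=O)c(F)c1` share one core and differ only in the group on the outer aromatic ring. In an assay on CHO cells for displacement of a labelled ligand from transient receptor potential cation channel subfamily V member 1 (Rattus norvegicus) (on this read-out lower numbers stand for stronger inhibition and higher numbers for weaker inhibition), compound 1 gives 660 nM, and compound 2 gives 411 nM. The step of a 1.6-fold lower number from compound 1 to compound 2 (0.21 log units; within the scatter) lies within the scatter, so the two compounds sit together rather than one clearly ahead of the other.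

Compound 3 `CC(C(=O)NCc1ccc(C2C=CCC2)cc1)c1ccc(NS(C)(=O)=O)c(F)c1` carries a further change at the same place: cyclopent-2-en-1-yl in place of cyclopropyl on an aromatic carbon. For the measured compounds named here, only one measured step bears on swapping the group at this position, namely a 1.6-fold lower number from compound 1 to compound 2 (0.21 log units; within the scatter), and it stayed within the scatter. Going by the values given here, no step yet shows what a five-membered ring at this place does. The expectation is therefore a step of modest size, a 1.2-fold lower number from compound 2 to compound 3 (0.07 log units; within the scatter), in either direction or none beyond the scatter. Compound 3 is expected to give about 350 nM in this assay, within a range from 120 nM to 1000 nM.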

Compound 3, inhibition constant: 162 nM
Beside the measured number, compound 3's estimate is 2.2-fold (0.33 log units) above it; low and high end bracket the measured number.
By their numbers in this assay, from the lowest: compound 3; then compounds 2 and 1 (each within the scatter of the next).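

At this position, on an aromatic carbon para to a large group, changing the group now moves the number in this assay beyond the scatter: the change to cyclopent-2-en-1-yl gives a 2.5-fold lower number from compound 2 to compound 3 (0.40 log units; beyond the scatter) and, set against trifluoromethyl, a 4.1-fold lower number from compound 1 to compound 3 (0.61 log units; beyond the scatter) as well. The position is therefore not indifferent to what sits on it, as the first pair alone might have suggested, and compound 3 has the lowest number of the three. Nothing measured here accounts for this gain.

Cyclopent-2-en-1-yl differs from cyclopropyl in both ring size and its double bond, so these compounds cannot separate the two, and saturated cyclopentyl would be the direct comparison. Also open, going by these compounds, is how a six-membered ring such as cyclohexyl or piperidine, or an open chain such as butyl, would behave here.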